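A few compounds are considered here, and "the series" means these few. Any claim that something is new, unique, unknown or untested is made for them only; others in the source may bear on it.

Among the compounds with values here, in an ADME assay on J774.1 cells (Mus musculus) for cytotoxicity, read by resazurin assay, with a stated time of 48 h (on this read-out lower numbers stand for stronger inhibition and higher numbers for weaker inhibition), compound 1 (`CCCn1cc(C(=O)NCc2ccccc2)c(=O)c2cc(F)c(N3CCC(C(N)=O)CC3)cc21`) gives 43700 nM, the only exact number available so far. Compound 2 (`CCCCn1cc(C(=O)O)c(=O)c2cc(F)c(N3CCC(C(N)=O)CC3)cc21`) reads > 100000 nM, and this is a limit of the assay, not a number. Compound 3 (`CCCn1cc(C(=O)NCc2ccco2)c(=O)c2cc(F)c(N3CCC(C(N)=O)CC3)cc21`) keeps the core of compound 1 and alters only the far end of the amide: furan-2-yl in place of phenyl on a saturated chain carbon bound to an amide-type nitrogen. In words, furan-2-yl takes the place of phenyl on a saturated chain carbon bound to an amide-type nitrogen. Within the data shown here, no measured pair shows what this swap does, so compound 1, at 43700 nM, is the sole anchor for the expectation. In this assay, the expected change is none beyond the scatter, with at most a slight drift towards weaker inhibition: the estimated step is a 1.1-fold higher number from compound 1 to compound 3 (0.06 log units; within the scatter). For compound 3, the expected value is 50000 nM, with an estimated range of 25000 nM to 100000 nM.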

Compound 3, half-maximal inhibitory concentration: 56900 nM
The estimate for compound 3 lay 1.1-fold (0.06 log units) below the measured number; measured number inside the range.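

In this assay, within the data shown here, furan-2-yl in place of phenyl on a saturated chain carbon bound to an amide-type nitrogen gives a 1.3-fold higher number from compound 1 to compound 3 (0.11 log units; within the scatter), the first step that can be read at this position. For this one pair, a five-membered aromatic ring with 1 hetero atom and a six-membered aromatic ring of carbon only cannot be told apart on this read-out. Nothing in the data shown accounts for this result.

The compounds shown leave open whether pyridin-2-yl or cyclohexyl in the same place, or phenethyl in place of benzyl, would move the number beyond the scatter. On these data alone, compound 2 reads > 100000 nM, which is a limit of the assay, and it differs from compound 1 in more than one place, so the separate contributions of its carboxylic acid and its butyl chain remain open.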